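The source may hold more compounds than are shown below. What is called first, only, known or untested is meant among the compounds shown, and "the series" means these compounds.

Measured in a functional assay on MV4-11 cells (Homo sapiens) for inhibition, read by resazurin assay, with a stated time of 72 h; on this read-out higher numbers stand for weaker inhibition of growth and lower numbers for stronger inhibition of growth:
- compound 1 `O=Cc1ccc(-c2cncc(Cl)c2N2CCC3(CCNC3=O)CC2)o1`: 5190 nM
- compound 2 `Cc1ccsc1-c1cncc(Cl)c1N1CCC2(CCNC2=O)CC1`: 910 nM
- compound 3 `Cc1csc(-c2cncc(Cl)c2N2CCC3(CCNC3=O)CC2)c1`: 650 nM

Compound 3 stands with compound 2 at the low end of these numbers. The a 1.4-fold lower number from compound 2 to compound 3 (0.15 log units; within the scatter) cannot separate the pair, whereas an 8.0-fold lower number from compound 1 to compound 3 (0.90 log units; beyond the scatter) is a clear gap. The next compound, compound 4 `O=C1NCCC12CCN(c1c(Cl)cncc1-c1ccc(Cl)s1)CC2`, keeps the shared core and differs from compound 3 in one group: 5-chlorothiophen-2-yl in place of 4-methylthiophen-2-yl on an aromatic carbon. The change lies on an aromatic carbon of a six-membered aromatic ring with one nitrogen.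

Among the measured compounds shown here, no measured compound carries 5-chlorothiophen-2-yl, so the evidence is indirect. The closest comparison is the exchange of 3-methylthiophen-2-yl for 4-methylthiophen-2-yl, a 1.4-fold lower number from compound 2 to compound 3 (0.15 log units; within the scatter), which stayed within the scatter. The larger 5.7-fold lower number from compound 1 to compound 2 (0.76 log units; beyond the scatter) and an 8.0-fold lower number from compound 1 to compound 3 (0.90 log units; beyond the scatter) both start from 5-formylfuran-2-yl, and that group is not a thiophene. For the measured compounds named here, compound 1, at 5190 nM, is also the only measured compound with a group named as substituted at the 5-position, which argues for leaving room towards higher numbers.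

No step beyond the scatter is therefore expected in this assay. The expected change is a 1.1-fold higher number from compound 3 to compound 4 (0.03 log units; within the scatter). For compound 4 the estimated value is 700 nM, with an expected range of 280 nM to 1800 nM.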

Compound 4, concentration for 50% growth inhibition: 560 nM
Estimate against measurement, compound 4: 1.3-fold (0.10 log units) above; the measured number falls inside the stated range.
By their numbers in this assay, from the lowest: compounds 4, 3 and 2 (each within the scatter of the next); then compound 1.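

In this assay, 5-chlorothiophen-2-yl on this aromatic carbon, ortho to a large group and two atoms from the ring nitrogen, gives a 1.2-fold lower number from compound 3 to compound 4 (0.06 log units; within the scatter) and a 1.6-fold lower number from compound 2 to compound 4 (0.21 log units; within the scatter), so a chloro group on the thiophene cannot be told apart here from either methyl-bearing thiophene. Among the compounds shown here, the earlier compounds left compound 1 as the only one with a group substituted at the 5-position, but a 9.3-fold lower number from compound 1 to compound 4 (0.97 log units; beyond the scatter) shows that a 5-substituted ring on this carbon can stand at the low end of the numbers, so substitution at the 5-position alone does not set compound 1 apart. Nothing measured here explains why the three thiophenes read alike or why compound 1 stands apart from them.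

The compounds shown leave open whether the gap to compound 1 follows the furan ring or the formyl group, which a thiophene carrying a formyl group or a furan carrying a chloro group would separate. They also leave open how a thiophene bearing an amine or a carboxylic acid, or a phenyl ring in place of the thiophene, would read on this carbon.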